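The compounds below may be only part of what the source reports. "The series", "measured", "known", "first", "only" and "open" are said of these compounds alone.

Measured in a functional assay on PC-3 cells (Homo sapiens) for cytotoxicity, read by MTT assay, with a stated time of 72 h; a lower number here means a stronger inhibitor, a higher number a weaker inhibitor:
- compound 1 `CNC(=O)c1cc(Oc2ccc(NC(=O)c3nccc(-c4ccccc4)n3)cc2)ccn1`: 7310 nM
- compound 2 `CNC(=O)c1cc(Oc2ccc(NC(=O)c3nccc(-c4cccc(Cl)c4)n3)cc2)ccn1`: 20800 nM
- compound 3 `CNC(=O)c1cc(Oc2ccc(NC(=O)c3nccc(-c4ccc(OC)cc4)n3)cc2F)ccn1`: 24300 nM

Compound 3 stands level with compound 2 within the scatter, and its number is higher than that of compound 1 by more than the scatter. The next compound to be tested is compound 4 `CNC(=O)c1cc(Oc2ccc(NC(=O)c3nccc(-c4ccc(OC)cc4)n3)cc2)ccn1`, which keeps the methoxy group of compound 3 but has hydrogen in place of fluoro on an aromatic carbon.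

Within the data shown here, no measured step covers this exchange. Among the measured compounds shown here, the only step available, a 2.8-fold higher number from compound 1 to compound 2 (0.45 log units; beyond the scatter), is a modest one for chloro in place of hydrogen at a different place in the molecule, so it bears on this change only loosely. Compound 1, which also carries no fluoro, gives 7310 nM, and this leans the expectation slightly towards a lower number in this assay. A small shift is therefore expected, most likely within the scatter, though a single measured step gives little support and the range must stay wide. The estimated step is a 1.5-fold lower number from compound 3 to compound 4 (0.18 log units; within the scatter). For compound 4 the expected value is 16000 nM, with an estimated range from 7000 nM to 32000 nM.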

Compound 4, half-maximal inhibitory concentration: 14200 nM
Beside the measured number, compound 4's estimate is 1.1-fold (0.05 log units) above it; low and high end bracket the measured number.
By their numbers in this assay, from the lowest: compounds 1, 4, 2 and 3 (each within the scatter of the next, the first and the last beyond it).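

In this assay, hydrogen in place of fluoro on the aromatic carbon ortho to a (2-(methylcarbamoyl)pyridin-4-yl)oxy group gives a 1.7-fold lower number from compound 3 to compound 4 (0.23 log units; within the scatter), the first step shown at this position, and it does not move the number beyond the scatter. Among these compounds, compound 4 also shows that a methoxy group on the phenyl ring does not separate clearly from the unsubstituted or the chloro compound: methoxy in place of hydrogen gives a 1.9-fold higher number from compound 1 to compound 4 (0.29 log units; within the scatter), and 4-methoxyphenyl in place of 3-chlorophenyl gives a 1.5-fold lower number from compound 2 to compound 4 (0.17 log units; within the scatter), whereas the chloro step alone, a 2.8-fold higher number from compound 1 to compound 2 (0.45 log units; beyond the scatter), is the one step here that passes beyond the scatter. No measurement on these compounds offers an explanation for these steps.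

Fluoro appears only together with 4-methoxyphenyl, so it remains open whether the same exchange would read alike with phenyl or 3-chlorophenyl in its place. Also open, as far as these compounds go, is how chloro or trifluoromethyl on that same aromatic carbon, or an amine or a carboxylic acid in place of methoxy on the phenyl ring, would read in this assay.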